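Swapping 4-Methoxyphenyl for 2-Hydroxyethyl: Cytotoxicity Expected to Fall Away

The source may report more compounds than this note shows. Statements on the series, on what has been measured and on what is new or still open speak of the compounds shown alone.

Of the compounds shown here, three sharing one core have been measured in an ADME assay on HFF cells (Homo sapiens) for cytotoxicity, read by MTT assay, with a stated time of 72 h; on this read-out higher numbers stand for weaker inhibition and lower numbers for stronger inhibition. Compound 1 `CC(C)(C)c1cn(C[C@H](O)[C@H]2OC(=O)C(OCc3ccccc3)=C2OCc2ccccc2)nn1` carries a tert-butyl group, and in this assay compound 1 gives 13300 nM. Compound 2 `O=C1O[C@H]([C@@H](O)Cn2cc(-c3cc(F)cc(F)c3)nn2)C(OCc2ccccc2)=C1OCc1ccccc1` carries a 3,5-difluorophenyl group instead. In this assay compound 2 returns > 100000 nM, which is a limit of the assay rather than a number (the limit of > 100000 nM in this assay, at which 1 of the 3 values shown sits). Compound 3 `COc1ccc(-c2cn(C[C@H](O)[C@H]3OC(=O)C(OCc4ccccc4)=C3OCc3ccccc3)nn2)cc1` carries a 4-methoxyphenyl group. In this assay compound 3 returns < 10 nM, again only a limit (the limit of < 10 nM in this assay, at which 1 of the 3 values shown sits). Compound 3 thus stands at the low end of everything shown: an at least 1300-fold lower number from compound 1 to compound 3 (3.12 log units; beyond the scatter) and an at least 10000-fold lower number from compound 2 to compound 3 (4.00 log units; beyond the scatter) are both large, while an at least 7.5-fold higher number from compound 1 to compound 2 (0.87 log units; beyond the scatter) is at least modest.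

Compound 4 `O=C1O[C@H]([C@@H](O)Cn2cc(CCO)nn2)C(OCc2ccccc2)=C1OCc1ccccc1` has not yet been measured. Its change from compound 3 is 2-hydroxyethyl in place of 4-methoxyphenyl on an aromatic carbon. Among the measured compounds shown here, the two large steps both have the 4-methoxyphenyl group entering; here it leaves, and no measured compound carries a 2-hydroxyethyl group, so the new group itself is uncharted. A large step upward in this assay is therefore expected, back toward the numbers of compound 1 and compound 2. Compound 4 is estimated at about 20000 nM, within 3000 nM to 100000 nM, which means an expected step of an at least 2000-fold higher number from compound 3 to compound 4 (3.30 log units; beyond the scatter).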

Compound 4, half-maximal inhibitory concentration: 58500 nM
The estimate for compound 4 lay 2.9-fold (0.47 log units) below the measured number; low and high end bracket the measured number.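

Compound 3 remains the only compound shown with a low number in this assay, and its value is a limit of the assay, not a number: the limit of < 10 nM in this assay, at which 1 of the 4 values shown sits.

Compound 4 now shows that this low reading does not persist when 4-methoxyphenyl leaves this aromatic carbon and 2-hydroxyethyl, which has no ring, takes its place, an at least 5800-fold higher number from compound 3 to compound 4 (3.76 log units; beyond the scatter), while a 4.4-fold higher number from compound 1 to compound 4 (0.64 log units; beyond the scatter) shows that the position also separates two groups without a ring, tert-butyl and 2-hydroxyethyl. Compound 4 cannot be firmly placed against compound 2, since the step, an at least 1.7-fold lower number from compound 2 to compound 4 (0.23 log units; that floor lies within the scatter), rests on a value that is only a limit of the assay: the limit of > 100000 nM in this assay, at which 1 of the 4 values shown sits.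

The compounds shown leave open whether the low reading belongs to the methoxy group or to the aromatic ring that carries it, a question that a plain phenyl, a 4-hydroxyphenyl or a 4-aminophenyl group would address. They also leave open whether a longer chain, or a chain ending in an amine or a carboxylic acid, would read like 2-hydroxyethyl, and they give no cause for the gap between compound 3 and the other three.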